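Chloro in place of fluoro: cytotoxicity outlook for compound 4

The source may hold more compounds than are shown below. What is called first, only, known or untested is meant among the compounds shown, and "the series" means these compounds.

Compound 3 `Cc1ccoc1C(=O)N1CCCn2nc(C(=O)Nc3ccc(F)cc3F)cc2C1` in an ADME assay on BEAS-2B cells (Homo sapiens) for cytotoxicity, read by fluorescence, with a stated time of 48 h (on this read-out higher numbers stand for lower toxicity in this test and lower numbers for higher toxicity in this test), gives 5000 nM. Among the three numbers measured it stands second highest: compound 2 `Cc1cc(C)c(C(=O)N2CCCn3nc(C(=O)Nc4ccccc4)cc3C2)o1` gives 2600 nM, within the scatter of compound 3, and compound 1 `O=C(Nc1ccccc1)c1cc2n(n1)CCCN(C(=O)c1occ3c1CCC3)C2` gives 10000 nM, also within the scatter of compound 3, so no order among the three can be read. Within the data shown here, the only step between compounds differing in one place, a 3.8-fold lower number from compound 1 to compound 2 (0.59 log units; beyond the scatter), concerns the group on the carbonyl carbon and leaves the amide side untouched, so it does not bear on the present change. Among the measured compounds shown here, compound 2 and compound 3 differ in more than one place and give no single step either. Compound 4 `Cc1ccoc1C(=O)N1CCCn2nc(C(=O)Nc3ccc(F)cc3Cl)cc2C1` differs from compound 3 by chloro in place of fluoro on an aromatic carbon. For the measured compounds named here, no measured step touches this position, so the expectation is a step within the scatter, a 1.3-fold lower number from compound 3 to compound 4 (0.10 log units; within the scatter), anchored on compound 3. The estimate for compound 4 is 4000 nM, with a range from 1500 nM to 10000 nM.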

Compound 4, half-maximal cytotoxic concentration: 30000 nM
The estimate for compound 4 lay 7.5-fold (0.88 log units) below the measured number; measured number above the stated range.
By their numbers in this assay, from the lowest: compounds 2, 3 and 1 (each within the scatter of the next, the first and the last beyond it); then compound 4.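

In this assay, chloro in place of fluoro on the aromatic carbon ortho to a large group, that is 2,4-difluorophenyl to 2-chloro-4-fluorophenyl, gives a 6.0-fold higher number from compound 3 to compound 4 (0.78 log units; beyond the scatter), in the direction of lower toxicity in this test. This position therefore responds to the exchange of a single halogen, and the series now has a step beyond the scatter at a place other than the group on the carbonyl carbon. Nothing at hand accounts for this step.

Going by these compounds, whether the step is particular to chloro stays open, since bromo, methyl or methoxy on the same aromatic carbon could give a step of another size or direction. Also open, on these data alone, is whether the same exchange gives a like step with another group on the carbonyl carbon of the shared core.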